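The source may report more compounds than this note shows. Statements on the series, on what has been measured and on what is new or still open speak of the compounds shown alone.

Three related amides were examined in a functional assay on a cell-free system (Platelet, plasma, Homo sapiens) for inhibition; on this read-out lower numbers stand for stronger inhibition and higher numbers for weaker inhibition. In this assay compound 1 `O=C(Nc1ccc(OCc2ccc(-c3ccccc3)cc2)cc1)C1CCCNC1` has the entry "not determined" (no result reported), and compound 2 `N=C(N)N1CCCC(C(=O)Nc2cccc(OCc3ccc(F)cc3)c2)C1` has the entry "not determined" (no result reported). Compound 3 `O=C(Nc1cccc(OCc2ccc(F)cc2)c1)C1CCNCC1` is the only one of the three with a number, at 36000 nM, so it cannot be ranked against the other two.

Compound 4 `O=C(Nc1cccc(OCc2ccc(-c3cc(F)cc(F)c3)cc2)c1)C1CCNCC1` has not yet been measured. It differs from compound 3 in one place: 3,5-difluorophenyl in place of fluoro on an aromatic carbon. In words, 3,5-difluorophenyl stands in place of fluoro on an aromatic carbon, para to a large group.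

Within the data shown here, no measured pair shows what a change of this kind does, so any expectation rests on very little. Compound 3 sits at 36000 nM, a weak value that leaves much more room for stronger inhibition than for weaker. A sizeable move toward lower numbers in this assay, beyond the usual scatter, is therefore expected, although a result within the scatter cannot be ruled out. The expected change is a 9.0-fold lower number from compound 3 to compound 4 (0.95 log units; beyond the scatter). For compound 4 the estimated value is 4000 nM, with an expected range from 400 nM to 40000 nM.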

Compound 4, half-maximal inhibitory concentration: 17000 nM
Compound 4: the middle estimate sits 4.3-fold (0.63 log units) below what was measured, and the stated range covers the measured number.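

In this assay, among these compounds, the replacement of fluoro by 3,5-difluorophenyl, on an aromatic carbon, para to a large group, gives a 2.1-fold lower number from compound 3 to compound 4 (0.33 log units; beyond the scatter) and is the first step that can be read. This position therefore takes 8 heavy atoms and one more six-membered aromatic ring in place of a single fluorine with no loss of inhibition, and the number moves modestly lower, although compound 4 at 17000 nM remains a weak inhibitor. Nothing at hand explains why the number moves in this direction.

The compounds shown leave open whether the added ring as a whole or its two fluorines account for the step, and a single pair cannot show how far the trend at this position extends. Also open, going by these compounds, is how an amine or a carboxylic acid on the added ring, or a longer alkyl chain in its place, would read in this assay when set against compound 4.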